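Silyl group removal from compound 3: working notes

The compounds below may be only part of what the source reports. "The series", "measured", "known", "first", "only" and "open" are said of these compounds alone.

Values in a functional assay on A2780 cells (Homo sapiens) for antiproliferative activity, read by sulforhodamine B assay, with a stated time of 48 h (on this read-out higher numbers stand for weaker inhibition of growth and lower numbers for stronger inhibition of growth), so far
compound 1 `COC(=O)/C=C/[C@H]1OCCC[C@@H]1O[Si](C)(C)C(C)(C)C` gives 28000 nM
compound 2 `O=C1C=C[C@H]2OCCC[C@H]2O1` gives 8300 nM
compound 3 `CC(C)(C)[Si](C)(C)O[C@@H]1CCCO[C@@H]1CC(=O)OCc1ccccc1` gives 23000 nM

Compound 3 and compound 1 lie within the scatter of each other. Compound 2 stands at a lower number than compound 3, beyond the scatter, so compound 3 sits in the upper part of this small set.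

Compound 4 (`O=C(C[C@H]1OCCC[C@H]1O)OCc1ccccc1`) differs from compound 3 by a hydrogen atom in place of a group of 7 heavy atoms (6 carbon, 1 silicon; no ring), on an oxygen on a saturated carbon, on an oxygen on a saturated carbon. Going by the values given here, no measured pair isolates this change. Compound 2 also lacks the group but differs elsewhere, so it does not settle the direction. In this assay a small step to a higher number is expected, estimated as a 1.5-fold higher number from compound 3 to compound 4 (0.18 log units; within the scatter) and within the scatter. Compound 4 is estimated at 35000 nM (12000 nM to 90000 nM).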

Compound 4, concentration for 50% growth inhibition: > 100000 nM
Compound 4 was reported as a limit (the forecaster's own chance of this, stated with the estimate: 15%); middle value at least 2.8-fold (0.45 log units) from the limit.
By their numbers in this assay, from the lowest: compound 2; then compounds 3 and 1 (each within the scatter of the next). At a limit, above all of these: compound 4.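

In this assay compound 4 gives > 100000 nM, a limit of the assay and not a number. Going by these compounds alone, this is the first pair that isolates the change: a hydrogen atom in place of the group of 7 heavy atoms (6 carbon, 1 silicon; no ring), on an oxygen on a saturated carbon, gives an at least 4.3-fold higher number from compound 3 to compound 4 (0.63 log units; beyond the scatter). At this position, in this pair, losing the group weakens inhibition of growth.

From the compounds shown here alone, the full size of the step stays open with only a limit for compound 4. Going by these compounds, whether a methyl or an acetyl group on this oxygen would behave like the group in compound 3 also stays open.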